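The source may hold more compounds than are shown below. What is called first, only, known or untested is meant among the compounds shown, and "the series" means these compounds.

In a functional assay (aorta) with Rattus norvegicus as the target (on this read-out higher numbers stand for weaker inhibition and lower numbers for stronger inhibition), compound 1 `CCCCN(CCCC)CCCCOc1ccc(S(=O)(=O)c2c(C(C)C)cn3ccccc23)cc1` gives 20.2 nM, while compound 2 `CC(C)(C)NCCCOc1ccc(S(=O)(=O)c2c(C(C)(C)C)cn3ccccc23)cc1` gives 443 nM. Compound 2 therefore holds the higher of the two numbers, and so the weaker inhibition, with a gap to compound 1 that lies beyond the scatter. Compound 3 `CC(C)c1cn2ccccc2c1S(=O)(=O)c1ccc(OCCCNC(C)(C)C)cc1` has not yet been measured. Its structure departs from that of compound 2 in one place: hydrogen in place of methyl on a saturated chain carbon bound to an aromatic carbon and two saturated chain carbons. In words, this is hydrogen in place of methyl on a saturated chain carbon bound to an aromatic carbon and two saturated chain carbons, which turns tert-butyl to isopropyl. Among the compounds with values here, no measured pair isolates this change, so the forecast is loose. It leans on the lower number of compound 1 at 20.2 nM, although that compound and compound 2 differ in more than one place. A moderate move toward stronger inhibition in this assay is expected, and the estimated change is a 3.7-fold lower number from compound 2 to compound 3 (0.57 log units; beyond the scatter). The expected value for compound 3 is 120 nM, with an estimated range of 30 nM to 450 nM.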

Compound 3, half-maximal inhibitory concentration: 41.8 nM
The estimate for compound 3 lay 2.9-fold (0.46 log units) above the measured number, within the range that was stated.
By their numbers in this assay, from the lowest: compound 1; then compound 3; then compound 2.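

In this assay, within the data shown here, hydrogen in place of methyl on a saturated chain carbon bound to an aromatic carbon and two saturated chain carbons, which turns tert-butyl to isopropyl, gives an 11-fold lower number from compound 2 to compound 3 (1.03 log units; beyond the scatter) and so isolates this change in a single pair for the first time. The step is large and shows that this one carbon on the group alone moves the read-out well beyond the scatter, something the earlier pair could not show as it differed in more than one place. With isopropyl held constant, (tert-butyl)amino in place of (dibutylamino)methyl on a saturated chain carbon, three bonds along the chain from an oxygen on an aromatic ring, gives a 2.1-fold higher number from compound 1 to compound 3 (0.32 log units; beyond the scatter) and this step is only modest, so of the two single changes the one at the isopropyl position is the larger. No measured property is available that bears on these steps.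

The compounds shown leave open how ethyl or cyclopropyl would read at this place. They also leave open whether tert-butyl to isopropyl would give a step of similar size in a compound carrying the (dibutylamino)methyl group.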